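A few compounds are considered here, and "the series" means these few. Any claim that something is new, unique, unknown or untested is made for them only; others in the source may bear on it.

Compound 1 `CC(C)CCc1ccc2c(NCCCNCc3ccco3)ccnc2c1` gives 9.47 in a physicochemical assay for acid dissociation.
Compound 2 `COc1ccc(F)cc1CNCCCNc1ccnc2cc(Cc3ccc(F)cc3)ccc12` gives 9.47 in this assay.
Compound 3 `COc1ccc(-c2ccc3c(NCCCNCc4ccco4)ccnc3c2)cc1` gives 9.47 in this assay.

Compound 3 stands level with compounds 1 and 2 at the digits shown: its nearest neighbour is compound 1 and its furthest is compound 2, and neither gap goes beyond the usual scatter of this kind of measurement. Compound 4 `Fc1ccc(Cc2ccc3c(NCCCNCc4ccco4)ccnc3c2)cc1` has not yet been measured. It differs from compound 3 in one place: 4-fluorobenzyl in place of 4-methoxyphenyl on an aromatic carbon. Going by the values given here, the only measured step that touches this position is the one that brought 4-methoxyphenyl in place of isopentyl, and it was flat: no change at the digits printed from compound 1 to compound 3 (within the scatter). Compound 2 already carries a 4-fluorobenzyl group on its core, and in this assay compound 2 sits at 9.47, the same level as the other two. Among the compounds with values here, nothing among the measured compounds shows the proton on the shared core being given up more or less readily when the group at this place is exchanged, so the expected step from compound 3 to compound 4 is no change at the digits printed from compound 3 to compound 4 (within the scatter), which is to say none beyond the scatter. Compound 4 is therefore estimated at 9.47, within a range from 9.2 to 9.75.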

Compound 4, acid dissociation constant: 9.47
Compound 4: middle estimate and measured number agree at the digits printed; low and high end bracket the measured number.
By their numbers in this assay, from the lowest: compounds 1, 2, 3 and 4 (each within the scatter of the next).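

In this assay, the swap at this aromatic carbon gives no change at the digits printed from compound 3 to compound 4 (within the scatter) even though the hydrogen-bond acceptor count of the group falls from 1 to 0, so a benzyl-type group with fluorine now stands alongside isopentyl and 4-methoxyphenyl without any shift beyond the scatter. The new compound also opens the chain side to comparison: furan-2-yl in place of 5-fluoro-2-methoxyphenyl on a saturated chain carbon bound to an amine nitrogen gives no change at the digits printed from compound 2 to compound 4 (within the scatter) and so this second place is flat as well. The last new pair agrees, with 4-fluorophenyl in place of isobutyl on a saturated chain carbon bound to an aromatic carbon giving no change at the digits printed from compound 1 to compound 4 (within the scatter) as its result.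

No available evidence accounts for this uniform reading. All the groups compared here carry no net charge, so it remains open whether an amine or a carboxylic acid on this aromatic carbon would shift the number, and the compounds shown also do not establish which site on the molecule gives up the proton.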